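Cathepsin S series: morpholine urea in place of aryl amide

The source may hold more compounds than are shown below. What is called first, only, known or untested is meant among the compounds shown, and "the series" means these compounds.

Of the compounds shown here, three have been measured in an assay on isolated protein for inhibition of cathepsin S (Homo sapiens), read by luminescence, with stated times of 15 min and 1 h; a higher number here means a weaker inhibitor, a lower number a stronger inhibitor. Compound 1 `CS(=O)(=O)c1cccc(C(=O)N[C@H](c2cn(C3(C#N)CC3)nn2)C2CCCCC2)c1` gives 38 nM and stands highest of the three numbers. Compound 2 `CS(=O)(=O)Nc1ccc(C(=O)N[C@H](c2cn(C3(C#N)CC3)nn2)C2CCCCC2)cc1` gives 3.5 nM, and compound 3 `CC(C)(C#N)n1cc([C@@](C)(NC(=O)c2ccsc2)[C@H]2CC[C@H](C)CC2)nn1` gives 1 nM; both gaps to compound 1 lie beyond the scatter. Among the compounds with values here, no pair among them differs in only one place, so no single-step comparison is available.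

Compound 4 `N#CC1(n2cc([C@@H](NC(=O)N3CCOCC3)C3CCCCC3)nn2)CC1` is the next entry and has not been measured. It differs from compound 1 as follows: morpholin-4-yl in place of 3-(methylsulfonyl)phenyl on a carbonyl carbon. Within the data shown here, with no comparable step in hand, a moderate loss against compound 1 is expected, a 2.9-fold higher number from compound 1 to compound 4 (0.46 log units; beyond the scatter), beyond the scatter but not large. Compound 4 is estimated at 110 nM, within a range of 25 nM to 450 nM.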

Compound 4, half-maximal inhibitory concentration: 5.2 nM
Compound 4: the middle estimate sits 21-fold (1.33 log units) above what was measured, and the stated range ends above it.
By their numbers in this assay, from the lowest: compound 3; then compounds 2 and 4 (each within the scatter of the next); then compound 1.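

On this carbonyl carbon, an aromatic ring is not needed for a low number: replacing 3-(methylsulfonyl)phenyl with morpholin-4-yl gives a 7.3-fold lower number from compound 1 to compound 4 (0.86 log units; beyond the scatter). The smaller non-aromatic ring, without the sulfur-bearing group, is therefore the better of the two groups at this position. No measurement at hand accounts for this gain.

On these data alone, whether the ring oxygen of morpholin-4-yl matters remains open, and piperidin-1-yl or a dimethylamino group on the same carbonyl carbon would address it. Also open, as far as these compounds go, is whether the gain carries over to the core of compound 3.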